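Hydroxamic Acid Replaces a Methylamide on the Chain

A few compounds are considered here, and "the series" means these few. Any claim that something is new, unique, unknown or untested is made for them only; others in the source may bear on it.

Compound 1 `CNC(=O)CCCCCCCn1nc(-c2ccc3oc(N)nc3c2)c2c(N)ncnc21` carries a long saturated chain ending in a methylamide on its core. In a functional assay on MCF7 cells (Homo sapiens) for inhibition, read by MTT assay, with a stated time of 72 h (a higher number here means a weaker inhibitor, a lower number a stronger inhibitor), compound 1 gives 7220 nM. For the measured compounds named here, this is the only plain number among the two values here; the other is a limit. Compound 2 `Nc1ncnc2c1c(-c1cnc3[nH]ccc3c1)nn2CCCC(=O)NO` has a different core and a shorter chain ending in a hydroxamic acid. In this assay compound 2 gives > 150000 nM, which is a limit of the assay and not a number. That value sits at the limit of > 150000 nM in this assay, at which 1 of the 2 values shown sits. Going by the values given here, no step between measured compounds that differ in one place exists, so the two values show only that compound 1 is measurably active while compound 2 is not within the range tested.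

Compound 3 `Nc1nc2cc(-c3nn(CCCCCC(=O)NO)c4ncnc(N)c34)ccc2o1` keeps the core of compound 1 and changes the chain end: hydroxycarbamoyl in place of 2-(methylcarbamoyl)ethyl on a saturated chain carbon, five bonds along the chain from an aromatic nitrogen. Among the compounds with values here, because compound 1 gives 7220 nM and no measured step shows what this exchange does, the expectation for compound 3 rests on compound 1 alone and carries a wide range. Compound 3 is expected near 6000 nM, between 1200 nM and 30000 nM. The step of a 1.2-fold lower number from compound 1 to compound 3 (0.08 log units; within the scatter) is expected to stay within the usual scatter.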

Compound 3, half-maximal inhibitory concentration: 12400 nM
The estimate for compound 3 lay 2.1-fold (0.32 log units) below the measured number, and the stated range covers the measured number.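

For the compounds shown here, this is the first pair that differs in one place: with the shared core kept, hydroxycarbamoyl in place of 2-(methylcarbamoyl)ethyl on a saturated chain carbon, five bonds along the chain from an aromatic nitrogen, gives in this assay a 1.7-fold higher number from compound 1 to compound 3 (0.23 log units; within the scatter). At this position, then, the two chain ends cannot be told apart in this cell assay, and a hydroxamic acid end does not by itself set compound 3 apart from compound 1. Nothing measured here gives a property of either chain end that would bear on this result.

This single pair says nothing yet about other ends at the same place, such as a carboxylic acid or an amine, or about hydroxycarbamoyl on a longer chain or a shorter one on this same core. Going by these compounds alone, compound 2 gives > 150000 nM, which is a limit of the assay and not a number, and since compound 2 differs from the others in more than one place, no step to it can be read.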